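Working notes: methoxy to chloro on the shared core

A few compounds are considered here, and "the series" means these few. Any claim that something is new, unique, unknown or untested is made for them only; others in the source may bear on it.

Measured in a functional assay, with a stated time of 150 min; on this read-out lower numbers stand for stronger inhibition and higher numbers for weaker inhibition:
compound 1 `CCOC(=O)c1cnn(-c2nc(-c3ccc(OC)cc3)c(C#N)c(=O)n2C)c1N` — 79 ug/mL
compound 2 `CSc1nc(-c2ccccc2O)c(C#N)c(=O)n1C` — 58 ug/mL
compound 3 `Cn1c(NN)nc(-c2ccco2)c(C#N)c1=O` — 65 ug/mL

Compound 1 gives the highest number of the three in this assay, but its gaps to compound 3 and to compound 2 both sit within the scatter, so the three cannot be ordered on these data. Going by the values given here, no pair among them differs in only one place, so no step between measured compounds is available.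

Compound 4 `CCOC(=O)c1cnn(-c2nc(-c3ccc(Cl)cc3)c(C#N)c(=O)n2C)c1N` is not yet measured. It differs from compound 1 as follows: chloro in place of methoxy on an aromatic carbon. Nothing measured here tracks chloro against methoxy at such a place, so the step in this assay is expected to be none beyond the scatter, with no direction favoured. Compound 4 is expected at 70 ug/mL, within 35 ug/mL to 140 ug/mL. That estimate means a 1.1-fold lower number from compound 1 to compound 4 (0.05 log units; within the scatter) is expected to be essentially flat.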

Compound 4, half-maximal inhibitory concentration: 87 ug/mL
For compound 4 the middle estimate is 1.2-fold (0.09 log units) below the measured one; low and high end bracket the measured number.
By their numbers in this assay, from the lowest: compounds 2, 3, 1 and 4 (each within the scatter of the next).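

In this assay, going by these compounds alone, the change from 4-methoxyphenyl to 4-chlorophenyl gives a 1.1-fold higher number from compound 1 to compound 4 (0.04 log units; within the scatter) and supplies the first one-place comparison. This position, on an aromatic carbon para to a large group, takes chloro or methoxy without a readable difference, although methoxy carries a hydrogen-bond acceptor and chloro none. No supporting measurement bears on this result. From the compounds shown here alone, whether an amine or a carboxylic acid at this place would move the number beyond the scatter stays open. So does whether the flat step holds with the rest of the shared core changed.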